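Thiosemicarbazone series: furan in place of methoxyphenyl

This account rests on a few compounds, and the source may have more. Where it says the series, first, only, none or still open, it means among the compounds named here.

Working notes on the series to date. Compound 1 `COc1ccc(/C=N/NC(=S)NC(C)(C)[C@H]2CC=C(C)CC2)cc1` gives 1200 nM in a functional assay on PC-3 cells (Homo sapiens) for inhibition, read by sulforhodamine B assay, with a stated time of 48 h (a lower number here means a stronger inhibitor of growth, a higher number a weaker inhibitor of growth), the lowest of the two numbers recorded so far. Compound 2 `COc1cc(/C=N/NC(=S)NC(C)(C)[C@H]2CC=C(C)CC2)ccc1O` gives 8300 nM in this assay; the gap between these two values lies beyond the scatter, so compound 1 stands as the stronger growth inhibitor of the pair.

Compound 3 `CC1=CC[C@H](C(C)(C)NC(=S)N/N=C/c2ccco2)CC1` has not yet been measured in this assay. Its change from compound 1 is furan-2-yl in place of 4-methoxyphenyl on a carbon with a double bond to nitrogen, with the shared core otherwise untouched. Among the measured compounds shown here, no measured pair in the set changes this aromatic group, so there is no precedent to lean on; the only measured pair varies a different part of the molecule.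

The expectation is a modest step in the weaker direction, which may still fall within the scatter, given that the core responsible for the recorded values of compound 1 and compound 2 is kept intact. The expected step is a 1.8-fold higher number from compound 1 to compound 3 (0.26 log units; within the scatter). Compound 3 is estimated at 2200 nM in this assay, with a likely range from 700 nM to 7000 nM.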

Compound 3, concentration for total growth inhibition: 27200 nM
For compound 3 the middle estimate is 12-fold (1.09 log units) below the measured one, and the stated range ends below it.
By their numbers in this assay, from the lowest: compound 1; then compound 2; then compound 3.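

In this assay, furan-2-yl in place of 4-methoxyphenyl on a carbon with a double bond to nitrogen gives a 23-fold higher number from compound 1 to compound 3 (1.36 log units; beyond the scatter), so with the shared core kept intact, this aromatic group has a large bearing on the read-out and the core alone does not set the value. The swap takes out a six-membered aromatic ring of carbon only, with 8 heavy atoms, and puts in a five-membered aromatic ring with 1 hetero atom, with 5 heavy atoms, while the counts of hydrogen-bond donors and acceptors and the net charge stay the same, so those counts do not distinguish the two groups. No measurement at hand bears on why the step is this large.

This single step changes the ring size, the ring atoms and the methoxy group all at once, so it cannot show which of these differences accounts for the step. An unsubstituted phenyl group would separate the contribution of the methoxy group from that of the ring, and thiophen-2-yl would test whether the step holds for another five-membered aromatic ring.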